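Working notes: one further chain step to compound 3

The source may report more compounds than this note shows. Statements on the series, on what has been measured and on what is new or still open speak of the compounds shown alone.

Compound 1 `[O-][S+](CCCCN=C=S)Cc1ccccc1`: 4850 nM
Compound 2 `[O-][S+](CCCCCN=C=S)Cc1ccccc1`: 5850 nM

Both values come from an ADME assay on Vero cells (Chlorocebus sabaeus) for cytotoxicity, read by MTT assay, with a stated time of 72 h; on this read-out lower numbers stand for stronger inhibition and higher numbers for weaker inhibition. Within the data shown here, the only measured step is a 1.2-fold higher number from compound 1 to compound 2 (0.08 log units; within the scatter), so compound 2 stands level with compound 1 on these numbers. No other measurement is available to place it.

Compound 3 `[O-][S+](CCCCCCN=C=S)Cc1ccccc1` has not yet been measured. Its structural difference from compound 2 is a group of 4 heavy atoms (2 carbon, 1 nitrogen, 1 sulfur; no ring) in place of a group of 3 heavy atoms (1 carbon, 1 nitrogen, 1 sulfur; no ring), on a saturated chain carbon, five bonds along the chain from a sulfur. Among the measured compounds shown here, the measured step from compound 1 to compound 2 is a replacement of the same kind, made four bonds along the chain from a sulfur rather than five, and it is the one step that bears on this change. For the measured compounds named here, with a 1.2-fold higher number from compound 1 to compound 2 (0.08 log units; within the scatter) as the sole guide, no step beyond the scatter is expected in this assay, and no direction can be claimed with confidence. The expected step is a 1.1-fold higher number from compound 2 to compound 3 (0.03 log units; within the scatter). The estimate for compound 3 is 6200 nM, with an expected range from 3200 nM to 11500 nM. The range is kept wide, as a single measured step offers little support.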

Compound 3, half-maximal inhibitory concentration: 4330 nM
Compound 3: middle estimate off by 1.4-fold (0.16 log units), on the high side; low and high end bracket the measured number.
By their numbers in this assay, from the lowest: compounds 3, 1 and 2 (each within the scatter of the next).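

In this assay, among these compounds, the replacement of a group of 3 heavy atoms by a group of 4 heavy atoms, now made five bonds along the chain from a sulfur, gives a 1.4-fold lower number from compound 2 to compound 3 (0.13 log units; within the scatter) and so does not repeat the direction of the single step made four bonds along the chain from a sulfur, although both steps stay within the scatter. Taken across the whole span, a larger group in place of a group of 3 heavy atoms, four bonds along the chain from a sulfur, gives a 1.1-fold lower number from compound 1 to compound 3 (0.05 log units; within the scatter) and thus shows that compound 1, compound 2 and compound 3 form a level set on this read-out, with no compound among the three going against that pattern. No measurement at hand offers an explanation for this level read-out.

From the compounds shown here alone, whether a longer chain would keep the read-out level remains open, as does the standing of an amine or a carboxylic acid placed on the same saturated chain carbon. Also open, going by these compounds, is whether the same chain replacement stays within the scatter on any read-out other than this assay.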